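Swapping Chloro for Nitro on a Shared Core

This account rests on a few compounds, and the source may have more. Where it says the series, first, only, none or still open, it means among the compounds named here.

Measured in an ADME assay on Vero cells (Chlorocebus sabaeus) for cytotoxicity, read by resazurin assay, with a stated time of 72 h; on this read-out higher numbers stand for weaker inhibition and lower numbers for stronger inhibition:
- Compound 1 `O=C(CCN1CCN(c2ccc([N+](=O)[O-])cc2)CC1)c1ccc(F)cc1`: 111000 nM
- Compound 2 `O=C(CCN1CCN(c2ccc(Cl)cc2)CC1)c1ccc(F)c(F)c1`: 86200 nM

In this assay, compound 2 at 86200 nM and compound 1 at 111000 nM lie within the usual scatter of each other. Compound 3 `O=C(CCN1CCN(c2ccc([N+](=O)[O-])cc2)CC1)c1ccc(F)c(F)c1` has nitro in place of chloro on an aromatic carbon of compound 2: nitro in place of chloro on an aromatic carbon. Going by the values given here, no measured pair shows this change alone. However, compound 1, which also carries 4-nitrophenyl, gives 111000 nM, so little movement is expected. The estimate means a 1.2-fold higher number from compound 2 to compound 3 (0.06 log units; within the scatter), which is expected to stay within the scatter. In this assay, the estimated value for compound 3 is 100000 nM, with an expected range from 55000 nM to 180000 nM.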

Compound 3, half-maximal inhibitory concentration: 122000 nM
Estimate against measurement, compound 3: 1.2-fold (0.09 log units) below; measured number inside the range.
By their numbers in this assay, from the lowest: compounds 2, 1 and 3 (each within the scatter of the next).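

Compounds 1 and 2 differ in two places, so neither group's contribution could be read from them. Compound 3 isolates each change: in this assay, nitro in place of chloro on the aromatic carbon gives a 1.4-fold higher number from compound 2 to compound 3 (0.15 log units; within the scatter) on its own. Fluoro in place of hydrogen on an aromatic carbon gives a 1.1-fold higher number from compound 1 to compound 3 (0.04 log units; within the scatter), so neither single change separates these compounds on this read-out.

Going by these compounds, whether a very different group at the nitro position, such as an amine or a carboxylic acid, would move the number beyond the scatter stays open. Nothing available here bears on why these compounds read so alike.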